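This account rests on a few compounds, and the source may have more. Where it says the series, first, only, none or still open, it means among the compounds named here.

Working notes on the amide series sharing the core of compound 1 `O=C(Nc1ccccc1)c1ccc(/N=N\c2c[nH]c3ccccc23)cc1`. In a functional assay on P388 cells (Mus musculus) for inhibition, read by MTT assay, with a stated time of 72 h (a higher number here means a weaker inhibitor, a lower number a stronger inhibitor), compound 1 gave "not active" (no number reported) and no number was obtained. Compound 2 `Cc1cccc(NC(=O)c2ccc(/N=N\c3c[nH]c4ccccc34)cc2)c1C` in this assay gives 51600 nM, the only numerical entry so far. Compound 3 `O=C(Nc1ccccc1Cl)c1ccc(/N=N\c2c[nH]c3ccccc23)cc1` in this assay likewise gave "not active" (no number reported), so no number places it on the scale; it shares this state with one further entry, compound 1. Compound 4 `Cc1ccc(C)c(NC(=O)c2ccc(/N=N\c3c[nH]c4ccccc34)cc2)c1` carries 2,5-dimethylphenyl in place of 2-chlorophenyl on an amide-type nitrogen. Within the data shown here, with no numerical step available between measured compounds, no direction can be fixed; compound 2, the one dimethylphenyl amide with a value, sits at the weak end, and a result for compound 4 of comparable size or no number at all is anticipated. Compound 4 in this assay is estimated at 60000 nM, expected between 20000 nM and 200000 nM.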

Compound 4, half-maximal inhibitory concentration: "not active" (no number reported)
Compound 4: no number reported; no gap can be computed for the estimate.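

No step can be read between compound 3 and compound 4, as neither has a number. The compounds shown leave open how the group on the amide-type nitrogen governs activity. No measured evidence bears on this result.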